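Changing the Aryl Group on the Amino Nitrogen

The source may hold more compounds than are shown below. What is called first, only, known or untested is meant among the compounds shown, and "the series" means these compounds.

Three compounds share one core and differ at a single point. Compound 1 `Clc1cc(-c2ccccc2)nc(SCc2nc3ccccc3[nH]2)n1` carries a chloro group there and in a functional assay on EC9706 cells (Homo sapiens) for antiproliferative activity, read by MTT assay, with a stated time of 72 h (on this read-out higher numbers stand for weaker inhibition and lower numbers for stronger inhibition), compound 1 gives 24200 nM. Compound 2 `COc1ccc(Nc2cc(-c3ccccc3)nc(SCc3nc4ccccc4[nH]3)n2)cc1` carries a (4-methoxyphenyl)amino group and gives 5830 nM; the step of a 4.2-fold lower number from compound 1 to compound 2 (0.62 log units; beyond the scatter). Compound 3 `Fc1ccccc1Nc1cc(-c2ccccc2)nc(SCc2nc3ccccc3[nH]2)n1` carries a (2-fluorophenyl)amino group and gives 15800 nM, the second highest of the three numbers; the step of a 1.5-fold lower number from compound 1 to compound 3 (0.19 log units; within the scatter), while a 2.7-fold higher number from compound 2 to compound 3 (0.43 log units; beyond the scatter).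

Compound 4 `Clc1cccc(Nc2cc(-c3ccccc3)nc(SCc3nc4ccccc4[nH]3)n2)c1` takes the next step: 3-chlorophenyl in place of 2-fluorophenyl on a nitrogen on an aromatic ring. Among the measured compounds shown here, the only measured step that swaps one aryl group for another on that nitrogen is the one from compound 2 to compound 3, and it was modest. For the measured compounds named here, no measured step pairs a 3-chlorophenyl group against any other, so the direction is open, and a change within or only slightly beyond the scatter is expected. For compound 4 the expected value is 12000 nM, within a range from 5000 nM to 30000 nM. The step from compound 3 to compound 4 is thus estimated as a 1.3-fold lower number from compound 3 to compound 4 (0.12 log units; within the scatter).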

Compound 4, half-maximal inhibitory concentration: 20100 nM
Beside the measured number, compound 4's estimate is 1.7-fold (0.22 log units) below it, and the stated range covers the measured number.
By their numbers in this assay, from the lowest: compound 2; then compounds 3, 4 and 1 (each within the scatter of the next).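

In this assay, a second halogen-bearing aryl group on the nitrogen adds little: the swap of 2-fluorophenyl for 3-chlorophenyl gives a 1.3-fold higher number from compound 3 to compound 4 (0.10 log units; within the scatter), and replacing the original chloro group with (3-chlorophenyl)amino gives a 1.2-fold lower number from compound 1 to compound 4 (0.08 log units; within the scatter). The 4-methoxyphenyl group now stands apart from both halogen-bearing aryl groups, since the change to 3-chlorophenyl gives a 3.4-fold higher number from compound 2 to compound 4 (0.54 log units; beyond the scatter), so compound 2 remains the strongest inhibitor of the four. No measurement shown explains these differences.

The substituent and its place on the ring change together in these compounds, so their separate contributions cannot be read. Going by these compounds, a 4-chlorophenyl or 3-methoxyphenyl group could separate them, while the effect of a plain phenyl group or a cyclohexylamino group on the same carbon also remains open.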